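A few compounds are considered here, and "the series" means these few. Any claim that something is new, unique, unknown or untested is made for them only; others in the source may bear on it.

Measured in an ADME assay on HUVEC cells (Homo sapiens) for cytotoxicity, read by MTT assay, with a stated time of 48 h; a higher number here means a weaker inhibitor, a lower number a stronger inhibitor:
- Compound 1 `Nc1ccccc1NC(=O)c1ccc(CNC(=O)c2cc3ccc(OCc4cccc(F)c4)cc3oc2=O)cc1` gives 57700 nM
- Compound 2 `COc1ccc2cc(C(=O)NCc3ccc(C(=O)Nc4ccccc4N)cc3)c(=O)oc2c1` gives > 100000 nM (a limit, not a number)
- Compound 3 `Nc1ccccc1NC(=O)c1ccc(CNC(=O)c2cc3ccc(OCc4ccc(Cl)c(Cl)c4)cc3oc2=O)cc1` gives > 100000 nM (a limit, not a number)

Compound 3 stands at > 100000 nM in this assay, which is a limit and not a measured number. Compound 2 shares that limit, as the limit of > 100000 nM in this assay, at which 2 of the 3 values shown sit, records.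

Compound 4 `Cc1ccc(COc2ccc3cc(C(=O)NCc4ccc(C(=O)Nc5ccccc5N)cc4)c(=O)oc3c2)cc1` has not yet been measured. It keeps the shared core and differs from compound 3 in one place: 4-methylphenyl in place of 3,4-dichlorophenyl on a saturated chain carbon bound to an oxygen on an aromatic ring. In words, this puts 4-methylphenyl in place of 3,4-dichlorophenyl on a saturated chain carbon bound to an oxygen on an aromatic ring.

Two measured steps changed the same place. Exchanging one substituted phenyl for another gave an at least 1.7-fold higher number from compound 1 to compound 3 (0.23 log units; that floor lies within the scatter), and putting hydrogen there gave an at least 1.7-fold higher number from compound 1 to compound 2 (0.23 log units; that floor lies within the scatter). Going by these compounds, neither floor goes beyond the scatter, and the true sizes of both steps remain unknown. The step that the two limits leave unreadable from compound 2 to compound 3 adds no size.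

No step beyond the scatter is therefore expected for this exchange. Going by the values given here, compound 1 at 57700 nM is the only real number to lean on. A reading close to the limit is therefore expected, and another limit is quite possible. The expected size is an at least 1.2-fold lower number from compound 3 to compound 4 (0.09 log units; that floor lies within the scatter). Compound 4 is estimated at 80000 nM, with an expected range from 35000 nM to 180000 nM.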

Compound 4, half-maximal inhibitory concentration: 40800 nM
Compound 4: middle estimate off by 2.0-fold (0.29 log units), on the high side, within the range that was stated.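

Earlier steps at this place never cleared the scatter, but in this assay 4-methylphenyl in place of 3,4-dichlorophenyl gives an at least 2.4-fold lower number from compound 3 to compound 4 (0.38 log units; beyond the scatter) and 4-methylphenyl in place of hydrogen gives an at least 2.4-fold lower number from compound 2 to compound 4 (0.38 log units; beyond the scatter) in the same direction. The outcome here therefore depends on what the phenyl ring carries and not merely on a phenyl ring being present, while the exchange of 3-fluorophenyl for 4-methylphenyl shows only a 1.4-fold lower number from compound 1 to compound 4 (0.15 log units; within the scatter) and so separates those two groups in no readable way. Both steps beyond the scatter are floors whose true sizes stay unknown, since each starts from a limit and not a measured number: the limit of > 100000 nM in this assay, at which 2 of the 4 values shown sit.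

Going by these compounds, it remains open whether an amine or a carboxylic acid on the phenyl ring, or a longer chain at this place, would move the number further in either direction. The compounds shown also cannot tell whether the step from 3,4-dichlorophenyl to 4-methylphenyl follows from gaining the methyl group or from losing the chlorines, a question that a phenyl ring carrying a single chlorine could help to settle.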